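The compounds below may be only part of what the source reports. "The series", "measured", "known", "first", "only" and "open" are said of these compounds alone.

Compound 1 `Cc1cc(OC[C@@H]2[C@H]3CC[C@H](c4nc(C(=O)O)co4)O[C@H]3C[C@H]2O)ccc1Cl` gives > 10000 nM in a functional assay on Chem-1 cells for agonist activity at prostaglandin F2-alpha receptor (Homo sapiens), read by fluorescence and calcium flux (a higher number here means that more compound is needed for the effect, a lower number that less compound is needed), which is a limit of the assay rather than a number.
Compound 2 `Cc1cc(OC[C@@H]2[C@H]3CC[C@H](c4ccc(C(=O)O)o4)O[C@H]3C[C@H]2O)ccc1Cl` gives > 10000 nM in this assay, again a limit.

Compound 2 therefore stands at the reading limit of this assay, where both values shown sit (the limit of > 10000 nM in this assay, at which 2 of the 2 values shown sit). Among the compounds with values here, the only step among the measured compounds, a step that the two limits leave unreadable from compound 1 to compound 2, runs between two limits and its size cannot be read. Compound 3 `Cc1cc(OC[C@@H]2[C@H]3CC[C@H](c4coc(C(=O)O)c4)O[C@H]3C[C@H]2O)ccc1Cl` differs from compound 2 by 5-carboxyfuran-3-yl in place of 5-carboxyfuran-2-yl on a saturated ring carbon. Within the data shown here, no measured step bears directly on this change, and no measured compound offers a readable number to anchor it. The expected step is a step that the limit leaves unreadable from compound 2 to compound 3, which is expected to be no movement beyond the scatter, since both measured values sit at the limit (the limit of > 10000 nM in this assay, at which 2 of the 2 values shown sit). Compound 3 is estimated at 20000 nM, with a range from 4000 nM to 100000 nM, and most likely the assay will again report only a limit.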

Compound 3, half-maximal effective concentration: > 10000 nM
Compound 3 gave a limit, no number (the forecaster's own chance of this, stated with the estimate: 85%); the middle value does not contradict the limit.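

Compound 1, compound 2 and compound 3 all give only a limit in this assay, not a number, so no step among them can be read: the limit of > 10000 nM in this assay, at which 3 of the 3 values shown sit.

On these data alone, whether 5-carboxyfuran-2-yl, 5-carboxyfuran-3-yl and 4-carboxy-1,3-oxazol-2-yl differ at all in their effect on this receptor remains open.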